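Chloro for fluoro on the second aryl ring of a diacylhydrazine

The compounds below may be only part of what the source reports. "The series", "measured", "known", "first", "only" and "open" are said of these compounds alone.

Measured compounds:
Compound 1, `CC(C)(C)N(NC(=O)c1ccccc1F)C(=O)c1ccccc1Cl`: 51.3 nM
Compound 2, `CC(C)(C)N(NC(=O)c1ccccc1Cl)C(=O)c1ccccc1Cl`: 331 nM
Compound 3, `CC(C)(C)N(NC(=O)c1ccc(F)cc1)C(=O)c1ccccc1Cl`: 389 nM

All three share one core and differ only in the aryl ring attached to one of the two carbonyl carbons. In an assay on cells for agonist activity at ecdysone receptor (Bombyx mori), read by a luciferase reporter, with a stated time of 24 h (on this read-out lower numbers stand for an effect already at smaller amounts and higher numbers for an effect only at larger amounts of compound), compound 1 gives 51.3 nM. Compound 2 differs from it by chloro in place of fluoro on an aromatic carbon, and the step of a 6.5-fold higher number from compound 1 to compound 2 (0.81 log units; beyond the scatter). Compound 3 differs from compound 1 by 4-fluorophenyl in place of 2-fluorophenyl on a carbonyl carbon, with a 7.6-fold higher number from compound 1 to compound 3 (0.88 log units; beyond the scatter). Between compound 2 and compound 3 the step of a 1.2-fold higher number from compound 2 to compound 3 (0.07 log units; within the scatter), so these two values cannot be told apart.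

Compound 4, `CC(C)(C)N(NC(=O)c1ccc(Cl)cc1)C(=O)c1ccccc1Cl`, is not yet measured. It differs from compound 3 by chloro in place of fluoro on an aromatic carbon. Among the compounds with values here, this is the same kind of change as the one from compound 1 to compound 2, but the place is not the same: there the new chloro sits ortho to a large group, here it sits para to a large group. Within the data shown here, because the only measured step of this kind, a 6.5-fold higher number from compound 1 to compound 2 (0.81 log units; beyond the scatter), was made at a different place, it is expected to carry over only in part. For compound 4 the estimated step is a 1.9-fold higher number from compound 3 to compound 4 (0.29 log units; within the scatter). Compound 4 is therefore expected to give about 750 nM in this assay, with a likely range from 250 nM to 2500 nM.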

Compound 4, half-maximal effective concentration: 115 nM
Estimate against measurement, compound 4: 6.5-fold (0.81 log units) above, and the stated range ends above it.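

In this assay, chloro in place of fluoro does not carry from one core to another in this series, since even the direction of the step reverses: the same change on two cores in this assay, a 6.5-fold higher number (0.81 log units; beyond the scatter) from compound 1 to compound 2 and a 3.4-fold lower number (0.53 log units; beyond the scatter) from compound 3 to compound 4, 22-fold (1.34 log units) apart, beyond the scatter of two such steps

On the ring that bears the halogen at the 4 position, chloro gives the lower number, and 4-chlorophenyl also compares well with 2-chlorophenyl, with a 3.4-fold lower number from compound 3 to compound 4 (0.53 log units; beyond the scatter) and a 2.9-fold lower number from compound 2 to compound 4 (0.46 log units; beyond the scatter), yet the 2-fluorophenyl ring keeps the lowest number of the four, with a 2.2-fold higher number from compound 1 to compound 4 (0.35 log units; beyond the scatter). These results rest on a single pair at each of the two places, so they warn against moving this change blindly from one core to another, but they give no reason for the reversal and no rule for any other ring.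

Still open, going by these compounds, is what a bromo, methyl or methoxy group, or a nitrile, would do on this ring, and whether such groups would also respond differently at the two places. Also open, on these data alone, is whether the reversal holds when the 2-chlorophenyl on the other carbonyl carbon is replaced by another ring.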